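The source may hold more compounds than are shown below. What is called first, only, known or untested is meant among the compounds shown, and "the series" means these compounds.

For the measured compounds named here, in a functional assay on the whole organism (integument) for inhibition, with Chilo suppressalis as the target, read by scintillation counting, with a stated time of 72 h (a lower number here means a stronger inhibitor, a higher number a weaker inhibitor), compound 2, `COc1cccc(OC)c1C(=O)Nc1nnc(-c2ccccc2)s1`, gives 2950 nM, and this is the only numerical value among the compounds described here. Going by the values given here, compound 1, `O=C(Nc1nnc(-c2ccc(Cl)cc2)s1)c1ccccc1Br`, differs from it in both aromatic substituents and is recorded in this assay only as a limit, > 5010 nM; that limit, (the limit of > 5010 nM in this assay, at which 1 of the 2 values shown sits), is all that is known of compound 1, so no step between the two measured compounds can be stated.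

Compound 3, `CCN(CC)c1ccc(-c2nnc(NC(=O)c3c(OC)cccc3OC)s2)cc1`, is not yet measured. It keeps the whole of compound 2 and changes one place: diethylamino in place of hydrogen on an aromatic carbon. Among the compounds with values here, no measured pair in this set shows such a change, so its effect has to be guessed without precedent. The diethylamino group is a substantial addition on the outer ring, and a step of modest size is expected in this assay, more likely toward a lower value than a higher one, though a result within the scatter of compound 2 cannot be excluded.

Compound 3 is therefore expected to give roughly 1500 nM in this assay, within a range of 400 nM to 6000 nM, which corresponds to an expected step of a 2.0-fold lower number from compound 2 to compound 3 (0.29 log units; within the scatter).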

Compound 3, half-maximal inhibitory concentration: 741 nM
Compound 3: middle estimate off by 2.0-fold (0.31 log units), on the high side; the measured number falls inside the stated range.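

Within this assay, replacing hydrogen with diethylamino gives a 4.0-fold lower number from compound 2 to compound 3 (0.60 log units; beyond the scatter) and thereby provides the first change at a single place that can be read in this set. It shows that this aromatic carbon, para to a large group, can carry diethylamino without loss of activity, and that the change moves the number beyond the scatter toward a stronger inhibitor. Nothing measured among these compounds explains the step.

For the compounds shown here, with only this one group at this place, it remains open whether a smaller amine such as dimethylamino, a cyclic amine such as morpholine, or a carboxylic acid would move the number in the same direction, and whether the step depends on the nitrogen or on the ethyl chains. Compound 1 is recorded only as a limit, > 5010 nM, and it differs from the other compounds in more than one place, so its steps cannot be read and it does not help to settle either question.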